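The compounds below may be only part of what the source reports. "The series", "measured", "known", "first", "only" and "open" are said of these compounds alone.

In a functional assay on PC-3 cells (Homo sapiens) for cytotoxicity, read by colorimetric assay (on this read-out lower numbers stand for stronger inhibition and higher numbers for weaker inhibition), compound 1 (`O=C(/C=C/c1ccc(CN2C(=O)/C(=C3\Nc4ccccc4\C3=N/O)c3cc(Cl)ccc32)cc1)NO`) gives 60 nM and stands level with compound 2 (`Cc1ccc2c(c1)/C(=C1/Nc3ccccc3/C1=N\O)C(=O)N2Cc1ccc(/C=C/C(=O)NO)cc1`), which gives 60 nM at the digits shown. Compound 3 (`O=C(NO)c1ccc(CN2C(=O)/C(=C3\Nc4ccccc4\C3=N/O)c3cc(Cl)ccc32)cc1`) has hydroxycarbamoyl in place of 2-(hydroxycarbamoyl)ethenyl on an aromatic carbon, counted as hydroxycarbamoyl in place of 2-(hydroxycarbamoyl)ethenyl on an aromatic carbon and with the rest of compound 1 unchanged. Going by the values given here, the only measured step of no change at the digits printed from compound 1 to compound 2 (within the scatter) concerns methyl in place of chloro, a different change, and so bears on this one only weakly. Among the compounds with values here, no step at this place has been measured, so a modest move towards weaker inhibition in this assay is expected, with wide uncertainty. The expected size is a 2.5-fold higher number from compound 1 to compound 3 (0.40 log units; beyond the scatter) in that direction. For compound 3 the estimate is 150 nM within an expected range of 50 nM to 500 nM in this read-out.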

Compound 3, half-maximal inhibitory concentration: 50 nM
Compound 3: the middle estimate sits 3.0-fold (0.48 log units) above what was measured; the range from low to high includes it.
By their numbers in this assay, from the lowest: compounds 3, 1 and 2 (each within the scatter of the next).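

In this assay, hydroxycarbamoyl in place of 2-(hydroxycarbamoyl)ethenyl gives a 1.2-fold lower number from compound 1 to compound 3 (0.08 log units; within the scatter). Going by these compounds alone, this is the first view of this position, where the earlier pair changed only chloro to methyl, and it shows that the shorter group on the aromatic carbon leaves the read-out within the scatter. Nothing available explains this result.

Going by these compounds, whether a carboxylic acid in place of hydroxycarbamoyl, or a longer chain carrying it, would stay level remains open. So does whether hydroxycarbamoyl behaves alike with methyl in place of chloro.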